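Trimming an Ester Arm: Cytotoxicity Outlook for Compound 4

This account rests on a few compounds, and the source may have more. Where it says the series, first, only, none or still open, it means among the compounds named here.

Compound 1 `O=C(CCl)Nn1c(S)nnc1COc1ccccc1C1=NOC(c2ccc(Cl)cc2Cl)C1`: 3.2 ug/mL in an ADME assay (MDM cells, Homo sapiens) for cytotoxicity, read by resazurin assay, with a stated time of 3 days; on this read-out higher numbers stand for weaker inhibition and lower numbers for stronger inhibition
Compound 2 `CCOC(=O)CC(=O)CSc1nnc(COc2ccccc2C2=NOC(c3ccc(Cl)cc3Cl)C2)n1NC(=O)CCl`: "not determined" (no result reported) in this assay
Compound 3 `CCOC(=O)CSc1nnc(COc2ccccc2C2=NOC(c3ccc(Cl)cc3Cl)C2)n1NC(C)=O`: "not determined" (no result reported) in this assay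

Compound 3 therefore stands without a number in this assay; among the measured set only compound 1 offers a number, and compound 2 offers none either. Compound 4 `CSc1nnc(COc2ccccc2C2=NOC(c3ccc(Cl)cc3Cl)C2)n1NC(C)=O` is the next step: hydrogen in place of ethoxycarbonyl on a saturated chain carbon bound to a sulfur. Within the data shown here, with no number for compound 3, no step can be anchored, and no shift beyond the usual scatter is expected in this assay from this structural change alone. The value of compound 1 is the nearest reference for the shared core. Compound 4 is expected to give 5 ug/mL, within a range from 1.5 ug/mL to 20 ug/mL.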

Compound 4, half-maximal inhibitory concentration: 2.7 ug/mL
Beside the measured number, compound 4's estimate is 1.9-fold (0.27 log units) above it; measured number inside the range.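

Among these compounds, compound 3 has no single number in this assay, and no step from it to compound 4 can be read. The compounds shown leave open what changing (ethoxycarbonyl)methyl to methyl does to this read-out. No further evidence bears on the result.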